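This account rests on a few compounds, and the source may have more. Where it says the series, first, only, none or still open, it means among the compounds named here.

Measured in a functional assay on the whole organism with Scenedesmus acutus as the target; a higher number here means a weaker inhibitor, a lower number a stronger inhibitor:
- compound 1 `COC(=O)c1cc(N2C(=O)C3=C(CCCC3)C2=O)c(F)cc1Cl`: 110 nM
- compound 2 `CCC(C)OC(=O)c1cc(N2C(=O)C3=C(CCCC3)C2=O)ccc1Cl`: 794 nM

Of these two, compound 2 has the higher number and is the weaker inhibitor, and its gap to compound 1 is beyond the scatter. Compound 3 `CCC(C)OC(=O)c1cc(N2C(=O)C3=C(CCCC3)C2=O)c(F)cc1Cl` is compound 2 with fluoro in place of hydrogen on an aromatic carbon. For the measured compounds named here, no measured step isolates this change. Going by the values given here, the only guide is compound 1 at 110 nM, which also has a fluoro group but carries a different group in place of the sec-butoxycarbonyl group, so it gives weak support. In this assay a moderate move to a lower number, beyond the scatter, is expected, and the estimated change is a 3.2-fold lower number from compound 2 to compound 3 (0.50 log units; beyond the scatter). For compound 3 the expected value is 250 nM, with an estimated range from 80 nM to 750 nM.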

Compound 3, half-maximal inhibitory concentration: 24.6 nM
Compound 3: the middle estimate sits 10-fold (1.01 log units) above what was measured, outside the stated range (below it).
By their numbers in this assay, from the lowest: compound 3; then compound 1; then compound 2.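

In this assay, for the compounds shown here, fluoro in place of hydrogen on the aromatic carbon para to a sec-butoxycarbonyl group gives a 32-fold lower number from compound 2 to compound 3 (1.51 log units; beyond the scatter), a large step and the first isolated reading of this change at this position. With the fluoro group in place in both compounds, sec-butyl in place of methyl on an oxygen next to a carbonyl group gives a 4.5-fold lower number from compound 1 to compound 3 (0.65 log units; beyond the scatter), a modest step that also favours the sec-butyl compound. No measurement bears on the reason for either step.

On these data alone, it remains open how large the fluoro step would be with methyl rather than sec-butyl on that oxygen. Also open, as far as these compounds go, is whether a methoxy group or a nitrile on the same aromatic carbon, or a longer chain on that oxygen, would move the number in the same direction.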